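The compounds below may be only part of what the source reports. "The series", "measured", "known", "first", "only" and "open" are said of these compounds alone.

Compounds measured in an assay on isolated protein for inhibition of 7-dehydrocholesterol reductase (Homo sapiens); a higher number here means a weaker inhibitor, a lower number a stronger inhibitor:

Compound 1 `Cc1cc(C)c(S(=O)(=O)N2CCC(N3CCC(C)CC3)CC2)c(C)c1` gives 50000 nM
Compound 2 `Cc1cc(C)c(S(=O)(=O)N2CCC(NCc3ccccc3)CC2)c(C)c1` gives 1070 nM
Compound 3 `Cc1cc(C)c(S(=O)(=O)N2CCC(N3CCCCCC3)CC2)c(C)c1` gives 1390 nM

Compound 1 stands at the highest number of the three in this assay. Both changes made at the same saturated ring carbon of its core moved the number strongly downward: a 47-fold lower number from compound 1 to compound 2 (1.67 log units; beyond the scatter) and a 36-fold lower number from compound 1 to compound 3 (1.56 log units; beyond the scatter). Between those two products the difference is small, a 1.3-fold higher number from compound 2 to compound 3 (0.11 log units; within the scatter), so in this assay compound 2 and compound 3 cannot be told apart.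

Compound 4 `Cc1cc(C)c(S(=O)(=O)N2CCC([N+]3(C)CCCC3)CC2)c(C)c1` has not yet been measured. Relative to compound 1 the change is a group of 6 heavy atoms (5 carbon, 1 nitrogen; one five-membered non-aromatic ring with 1 hetero atom) in place of a group of 7 heavy atoms (6 carbon, 1 nitrogen; one six-membered non-aromatic ring with 1 hetero atom), on a saturated ring carbon. The two measured steps from compound 1 both replace the same 4-methylpiperidin-1-yl group at this position and both were large, but neither introduced a group carrying a net charge or a five-membered ring, so they bear on the new step only in part. On that basis a downward step is expected in this assay, a 5.0-fold lower number from compound 1 to compound 4 (0.70 log units; beyond the scatter), though smaller than the measured ones. The estimate for compound 4 is 10000 nM, within a range from 1500 nM to 60000 nM.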

Compound 4, half-maximal inhibitory concentration: 50000 nM
Compound 4: the middle estimate sits 5.0-fold (0.70 log units) below what was measured; the range from low to high includes it.
By their numbers in this assay, from the lowest: compounds 2 and 3 (each within the scatter of the next); then compounds 1 and 4 (each within the scatter of the next).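

In this assay this swap gives no change at the digits printed from compound 1 to compound 4 (within the scatter) and so, on this saturated ring carbon, the five-membered ring group with net charge +1 stands level with 4-methylpiperidin-1-yl. It stands well apart from the azepan-1-yl and benzylamino groups, with a 36-fold higher number from compound 3 to compound 4 (1.56 log units; beyond the scatter) and a 47-fold higher number from compound 2 to compound 4 (1.67 log units; beyond the scatter) so replacing 4-methylpiperidin-1-yl does not by itself bring the number down, and absence of net charge does not suffice either, as compound 1 carries none. No measurement at hand accounts for these differences.

On these data alone, whether the net charge or the five-membered ring matters here stays open; a pyrrolidin-1-yl group without the added methyl would speak to that. Also open, as far as these compounds go, is what the methyl of 4-methylpiperidin-1-yl contributes, which a plain piperidin-1-yl group would test.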